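The source may report more compounds than this note shows. Statements on the series, on what has been measured and on what is new or still open speak of the compounds shown alone.

Compound 1 `NC1=NC2(CCOCC2)N(OCCCOc2ccc(Cl)c(Cl)c2)C(N)=N1`: 8.23 nM in an assay on isolated protein for inhibition of Dihydrofolate reductase (Homo sapiens), read by spectrophotometry, using NADPH, with stated times of 5 s and 6 min; a lower number here means a stronger inhibitor, a higher number a weaker inhibitor
Compound 2 `NC1=NC2(CCOCC2)N(OCCCOc2cc(Cl)c(Cl)cc2Cl)C(N)=N1`: 36 nM in this assay

For the measured compounds named here, compound 2 gives the highest number of the two in this assay; its only neighbour is compound 1, and the step of a 4.4-fold higher number from compound 1 to compound 2 (0.64 log units; beyond the scatter) lies beyond the scatter. Compound 3 `NC1=NC2(CCOCC2)N(OCCCOc2ccc(Br)cc2)C(N)=N1` has not been measured in this assay. It differs from compound 2 as follows: 4-bromophenyl in place of 2,4,5-trichlorophenyl on an oxygen on a saturated carbon. Going by the values given here, no measured step covers this change directly. Among the compounds with values here, the single step available, a 4.4-fold higher number from compound 1 to compound 2 (0.64 log units; beyond the scatter), shows that an added chloro raised the number; compound 3 carries bromine alone where compound 2 carries its chlorines, so a return toward the lower number of compound 1 is expected, though the exchange of chlorine for bromine is untested and the size of the move is uncertain. The expected step is a 2.4-fold lower number from compound 2 to compound 3 (0.38 log units; beyond the scatter). Compound 3 is estimated at 15 nM, with a range of 5 nM to 50 nM.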

Compound 3, half-maximal inhibitory concentration: 32.5 nM
For compound 3 the middle estimate is 2.2-fold (0.34 log units) below the measured one; the range from low to high includes it.
By their numbers in this assay, from the lowest: compound 1; then compounds 3 and 2 (each within the scatter of the next).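

In this assay, the step of a 1.1-fold lower number from compound 2 to compound 3 (0.04 log units; within the scatter) shows that 4-bromophenyl and 2,4,5-trichlorophenyl on this oxygen cannot be told apart, even though the two groups carry different halogens and differ in heavy-atom count. The step of a 3.9-fold higher number from compound 1 to compound 3 (0.60 log units; beyond the scatter) shows that a single bromine does not restore the number of compound 1, so across these three compounds the number does not simply follow the count of halogens: 3,4-dichlorophenyl alone stands apart, while compound 2 and compound 3 carry the most and the fewest halogens. Nothing at hand bears on the reason for these steps.

The compounds shown leave open whether the step from compound 1 to compound 3 follows from the change of halogen or from the loss of a ring substituent, which 4-chlorophenyl would help to separate. They also leave open how this position responds to a group other than a halogen, such as an amine or a carboxylic acid on the aromatic ring.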